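Chain lengthening on a dichloro/fluorochloro purine series

The compounds below may be only part of what the source reports. "The series", "measured", "known", "first", "only" and "open" are said of these compounds alone.

Measured compounds:
Compound 1 `CCCCC(CCO)n1cnc2c(Cl)nc(Cl)nc21` — 15500 nM
Compound 2 `CCCCCC(CCO)n1cnc2c(Cl)nc(Cl)nc21` — 6170 nM
Compound 3 `CCCCCCC(CCO)n1cnc2c(Cl)nc(F)nc21` — 9960 nM

In a functional assay on HCT-116 cells (Homo sapiens) for antiproliferative activity, read by MTT assay, with a stated time of 48 h (a lower number here means a stronger inhibitor, a higher number a weaker inhibitor), compound 1 gives 15500 nM, and compound 2 gives 6170 nM. The change between them is methyl in place of hydrogen on a saturated chain carbon, five bonds along the chain from an aromatic nitrogen, and it made a 2.5-fold lower number from compound 1 to compound 2 (0.40 log units; beyond the scatter). Compound 3 gives 9960 nM in this assay; how the core of compound 3 differs from the core of compound 1 is not broken down here. Compound 4 `CCCCCCCC(CCO)n1cnc2c(Cl)nc(F)nc21` has not been measured. It differs from compound 3 by methyl in place of hydrogen on a saturated chain carbon, seven bonds along the chain from an aromatic nitrogen, the same kind of change as that from compound 1 to compound 2, though here on a saturated chain carbon seven bonds along the chain from an aromatic nitrogen rather than five. Because a 2.5-fold lower number from compound 1 to compound 2 (0.40 log units; beyond the scatter) was modest, a step of about a 1.8-fold lower number from compound 3 to compound 4 (0.26 log units; within the scatter) is expected. Compound 4 is estimated at 5500 nM, between 2500 nM and 12000 nM.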

Compound 4, half-maximal inhibitory concentration: 17600 nM
The estimate for compound 4 lay 3.2-fold (0.51 log units) below the measured number; the measured number lies above the stated range.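

In this assay methyl in place of hydrogen gave a 1.8-fold higher number from compound 3 to compound 4 (0.25 log units; within the scatter) and so did not repeat the lower number seen on the core of compound 1. The same change therefore did not carry over as a constant step, and the two steps differ: the same change on two cores in this assay, a 2.5-fold lower number (0.40 log units; beyond the scatter) from compound 1 to compound 2 and a 1.8-fold higher number (0.25 log units; within the scatter) from compound 3 to compound 4, 4.4-fold (0.65 log units) apart, beyond the scatter of two such steps. This does not show why they differ, as the change sits five bonds along the chain in one pair and seven in the other, and the data cannot separate that place from the core.

The compounds shown leave open how the chain of compound 3 or compound 4 would behave on the core of compound 1. They also leave open whether a longer chain, an amine or a carboxylic acid on the chain would shift these numbers.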